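A few compounds are considered here, and "the series" means these few. Any claim that something is new, unique, unknown or untested is made for them only; others in the source may bear on it.

Compound 2 `O=C(/C=C/C(=O)N1C/C(=C\c2ccc([N+](=O)[O-])cc2)C(=O)/C(=C/c2ccc([N+](=O)[O-])cc2)C1)Nc1ccc([N+](=O)[O-])cc1` stands lowest of the three numbers measured in a functional assay on L1210 cells (Mus musculus) for cytotoxicity; a higher number here means a weaker inhibitor, a lower number a stronger inhibitor: compound 2 gives 1000 nM, whereas compound 3 `O=C(/C=C/C(=O)N1C/C(=C\c2ccccc2)C(=O)/C(=C/c2ccccc2)C1)Nc1ccccc1` gives 3600 nM and compound 1 `O=C(/C=C/C(=O)N1C/C(=C\c2ccccc2)C(=O)/C(=C/c2ccccc2)C1)Nc1ccc([N+](=O)[O-])cc1` gives 40000 nM. Compound 4 `Cc1ccc(NC(=O)/C=C/C(=O)N2C/C(=C\c3ccc([N+](=O)[O-])cc3)C(=O)/C(=C/c3ccc([N+](=O)[O-])cc3)C2)cc1` differs from compound 2 by methyl in place of nitro on an aromatic carbon, so the (4-nitrophenyl)amino part of compound 2 becomes (4-methylphenyl)amino in compound 4.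

Going by the values given here, one measured step bears on this part of the molecule: an 11-fold lower number from compound 1 to compound 3 (1.05 log units; beyond the scatter). Among the compounds with values here, that step took place in a pair whose shared core carries unsubstituted phenyl groups, while compound 2 and compound 4 carry nitro groups on those phenyls; no measured pair shows methyl entering in place of nitro anywhere. Within the data shown here, what the data show is that removing the nitro from that amino-bearing ring lowered the number strongly in the only pair where it was tried, and that nitro groups on the core phenyls gave compound 2 a lower number than compound 3.

Compound 4 is therefore expected to give a lower number than compound 2 in this assay, though methyl is not hydrogen and the size of the step is uncertain. The expected step is a 3.3-fold lower number from compound 2 to compound 4 (0.52 log units; beyond the scatter). Compound 4 is estimated at 300 nM, with a range from 80 nM to 1500 nM.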

Compound 4, half-maximal inhibitory concentration: 4400 nM
Beside the measured number, compound 4's estimate is 15-fold (1.17 log units) below it; the whole stated range lies below it.
By their numbers in this assay, from the lowest: compound 2; then compounds 3 and 4 (each within the scatter of the next); then compound 1.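

In this assay, putting methyl in place of the nitro of the (4-nitrophenyl)amino part gave a 4.4-fold higher number from compound 2 to compound 4 (0.64 log units; beyond the scatter), so losing this nitro does not lower the number in every setting. Going by these compounds alone, the only earlier step at this position ran the other way, an 11-fold lower number from compound 1 to compound 3 (1.05 log units; beyond the scatter), but there hydrogen entered rather than methyl and the phenyl groups of the shared core carried no nitro, so the two steps differ in both the entering group and the core. The direction of a change at this position therefore cannot be carried from one core to the other on the strength of the earlier pair alone. No measurement available here explains why the two steps point in opposite directions.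

The compounds shown leave open whether the entering group or the nitro groups on the core phenyls set that direction, since hydrogen at this position on the nitro-bearing core and methyl on the unsubstituted core would separate the two. Also open, as far as these compounds go, is where other groups at this place, such as an amine, a methoxy group or a chlorine atom, would fall relative to nitro and methyl on the core of compound 2.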